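Working notes: Vero cell cytotoxicity, compounds 1 to 3

The source may hold more compounds than are shown below. What is called first, only, known or untested is meant among the compounds shown, and "the series" means these compounds.

Measured so far:
compound 1 `O=C(c1ccncc1)N1N=C(c2cc3ccccc3o2)CC1c1ccc(O)cc1`: > 200000 nM
compound 2 `CCn1cc(C(=O)N2N=C(c3cc4ccccc4o3)CC2c2ccc(OC)cc2O)c(=O)c2ccc(C)nc21`: > 154000 nM

In an ADME assay on Vero cells (Chlorocebus sabaeus) for cytotoxicity, read by MTT assay, with a stated time of 72 h (a lower number here means a stronger inhibitor, a higher number a weaker inhibitor), compound 1 gives > 200000 nM, a limit of the assay. Compound 2 gives > 154000 nM, also a limit. Compound 2 thus sits at the limit of > 154000 nM in this assay, at which 1 of the 2 values shown sits. Compound 1 sits at the limit of > 200000 nM in this assay, at which 1 of the 2 values shown sits. Compound 3 `CCn1cc(C(=O)N2N=C(c3cc4ccccc4o3)CC2c2ccco2)c(=O)c2ccc(C)nc21` differs from compound 2 by furan-2-yl in place of 2-hydroxy-4-methoxyphenyl on a saturated ring carbon. Among the measured compounds shown here, no measured step covers this change, and no shift beyond the scatter is expected in this assay. Compound 3 is expected to give 200000 nM, with a range of 100000 nM to 400000 nM, most likely again as a limit. The expected step from compound 2 to compound 3 is a step that the limit leaves unreadable from compound 2 to compound 3.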

Compound 3, half-maximal inhibitory concentration: > 185000 nM
Compound 3: only a limit was reported; the forecaster's own chance of this, stated with the estimate: 85%; the middle value is on the limit's open side.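

In this assay compound 3 gives > 185000 nM, a limit. Compound 2 gives > 154000 nM, also a limit, and the step between the two cannot be read. The compounds shown leave open where the actual half-maximal inhibitory concentration of each lies.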